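From Piperidine Urea to Benzyl Oxalamide: Expected Cytotoxicity

The source may report more compounds than this note shows. Statements on the series, on what has been measured and on what is new or still open speak of the compounds shown alone.

Measured compounds:
Compound 1 `COc1ccc(/C(=C(/CCNC(=O)NCc2ccccc2)c2ccccc2)c2ccccc2)cc1`: in a functional assay on MDA-MB-231 cells (Homo sapiens) for cytotoxicity, read by MTT assay, with a stated time of 72 h (on this read-out higher numbers stand for weaker inhibition and lower numbers for stronger inhibition), compound 1 gives > 50000 nM, a limit of the assay.
Compound 2 `CCN(CC)C(=O)NCC/C(=C(\c1ccccc1)c1ccc(OC)cc1)c1ccccc1`: in this assay compound 2 gives 40700 nM.
Compound 3 `COc1ccc(/C(=C(/CCNC(=O)N2CCCCC2)c2ccccc2)c2ccccc2)cc1`: in this assay compound 3 gives > 50000 nM, a limit of the assay.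

Compound 3 therefore has no exact number, only a limit, and it shares that position with compound 1, as the limit of > 50000 nM in this assay, at which 2 of the 3 values shown sit, shows. The three compounds differ only in the group on the urea carbonyl carbon, and the measured steps are small: an at least 1.2-fold lower number from compound 1 to compound 2 (0.08 log units; that floor lies within the scatter) and an at least 1.2-fold higher number from compound 2 to compound 3 (0.08 log units; that floor lies within the scatter), both within the scatter, while a step that the two limits leave unreadable from compound 1 to compound 3.

Compound 4 `COc1ccc(/C(=C(/CCNC(=O)C(=O)NCc2ccccc2)c2ccccc2)c2ccccc2)cc1` is reached from compound 3 by benzylcarbamoyl in place of piperidin-1-yl on a carbonyl carbon. The new group brings back the benzyl amide found in compound 1, with an extra carbonyl inserted, so the closest guide is compound 1, whose value is a limit. Among the compounds with values here, no measured step in this set moves a compound clearly away from the limit, so compound 4 is expected to stay in the same weak region, with a number no higher from compound 3 to compound 4 (the limit leaves the size open) expected as the step. The estimate for compound 4 in this assay is 50000 nM, spanning 20000 nM to 150000 nM.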

Compound 4, half-maximal inhibitory concentration: 11500 nM
Beside the measured number, compound 4's estimate is 4.3-fold (0.64 log units) above it; the measured number lies below the stated range.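

Until now, changing the group on the urea carbonyl carbon had moved nothing beyond the scatter in this assay, whereas benzylcarbamoyl in place of piperidin-1-yl gives an at least 4.3-fold lower number from compound 3 to compound 4 (0.63 log units; beyond the scatter). The other two ureas tell the same story, with a 3.5-fold lower number from compound 2 to compound 4 (0.55 log units; beyond the scatter) and an at least 4.3-fold lower number from compound 1 to compound 4 (0.63 log units; beyond the scatter), so compound 4 is the most potent of the four, though only by a modest margin. Compound 1 and compound 4 both carry the benzyl group and differ by one inserted carbonyl, so the benzyl group alone does not go with the lower number, and the steps starting from compound 1 and compound 3 give only floors, not full sizes: the limit of > 50000 nM in this assay, at which 2 of the 4 values shown sit.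

The compounds shown leave open whether the inserted carbonyl would give a similar step with piperidin-1-yl or diethylamino on it, and whether a phenethyl or pyridylmethyl group in place of benzyl would lower the number further. The step from compound 1 to compound 3 cannot be read, since both values are limits.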